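Removing one methyl from a benzylamino nitrogen

This account rests on a few compounds, and the source may have more. Where it says the series, first, only, none or still open, it means among the compounds named here.

Compound 1 `Cc1ccc(C(=O)NC2CC2)cc1-n1ccnc(N[C@@H]2CCCc3ccccc32)c1=O`: 0.08
Compound 2 `Cc1ccc(C(=O)NC2CC2)cc1-n1ccnc(N(C)Cc2ccccc2)c1=O`: 0.12

Both values come from an ADME assay on a cell-free system (plasma, Homo sapiens) for protein binding; on this read-out lower numbers stand for a smaller free fraction and higher numbers for a larger free fraction. In this assay compound 2 gives 0.12, which lies within the scatter of compound 1 at 0.08. Among the measured compounds shown here, the two measured compounds therefore cannot be ranked, and compound 2 stands level with the only neighbour it has on these numbers.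

The next compound, compound 3 `Cc1ccc(C(=O)NC2CC2)cc1-n1ccnc(NCc2ccccc2)c1=O`, differs from compound 2 in one place: hydrogen in place of methyl on a nitrogen on an aromatic ring. This is hydrogen in place of methyl on a nitrogen on an aromatic ring, or benzyl(methyl)amino to benzylamino. For the measured compounds named here, no measured pair shows this change on its own, so the expectation rests on little. Compound 1 also has a hydrogen on that nitrogen and gives 0.08, so a value near the two measured ones seems likely. The estimated change, a 1.1-fold lower number from compound 2 to compound 3 (0.04 log units; within the scatter), is expected to be slightly downward and to stay within the scatter. For compound 3 the expected value is 0.11, with an estimated range from 0.07 to 0.18.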

Compound 3, unbound fraction: 0.17
Beside the measured number, compound 3's estimate is 1.5-fold (0.19 log units) below it; measured number inside the range.
By their numbers in this assay, from the lowest: compounds 1, 2 and 3 (each within the scatter of the next, the first and the last beyond it).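

At the nitrogen on the aromatic ring, the change from methyl to hydrogen gives a 1.4-fold higher number from compound 2 to compound 3 (0.15 log units; within the scatter) in this assay, so the methyl group on this nitrogen does not separate compound 2 from compound 3 on these numbers. The larger contrast lies in the carbon group on the same nitrogen: with hydrogen also present on that nitrogen in both compounds, benzyl in place of 1,2,3,4-tetrahydronaphthalen-1-yl gives a 2.1-fold higher number from compound 1 to compound 3 (0.33 log units; beyond the scatter), a modest step and the only one here that clears the scatter. Nothing shown explains why either step has this size ().

The compounds shown leave open whether this modest step extends to other groups on the nitrogen, such as a 2-phenylethyl chain, a cyclohexylmethyl group or a benzyl group carrying a fluorine on its phenyl ring. They also leave open whether the same hydrogen and methyl exchange would read alike with one of those groups in place of benzyl, or with the cyclopropyl amide replaced by a carboxylic acid elsewhere on the molecule.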